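Bromine for chlorine on the ester aryl group

The source may hold more compounds than are shown below. What is called first, only, known or untested is meant among the compounds shown, and "the series" means these compounds.

Compound 1 `COC(=O)c1cc(Cl)ccc1OC(=O)COc1cc(O)c2c(=O)cc(-c3ccccc3)oc2c1` carries a 4-chloro-2-(methoxycarbonyl)phenyl group on an oxygen next to a carbonyl group of a shared core. In an ADME assay on cells (T-cell, Mus musculus, strain BALB/c) for cytotoxicity, read by MTT assay, with a stated time of 48 h (a higher number here means that more compound is tolerated, a lower number that less compound is tolerated), compound 1 gives > 436000 nM, which is a limit of the assay and not a number; this is the limit of > 436000 nM in this assay, at which 1 of the 3 values shown sits. Compound 2 `COC(=O)c1ccc(C)cc1OC(=O)COc1cc(O)c2c(=O)cc(-c3ccccc3)oc2c1` gives 250000 nM and compound 3 `COC(=O)c1cc(O)ccc1OC(=O)COc1cc(O)c2c(=O)cc(-c3ccccc3)oc2c1` gives 263000 nM. The steps of an at least 1.7-fold lower number from compound 1 to compound 2 (0.24 log units; that floor lies within the scatter) and an at least 1.6-fold lower number from compound 1 to compound 3 (0.21 log units; that floor lies within the scatter) both start from that limit, and a 1.1-fold higher number from compound 2 to compound 3 (0.02 log units; within the scatter) separates the two measured neighbours. Compound 4 `COC(=O)c1ccc(Br)cc1OC(=O)COc1cc(O)c2c(=O)cc(-c3ccccc3)oc2c1` differs from compound 1 by a group of 11 heavy atoms (8 carbon, 2 oxygen, 1 bromine; one six-membered aromatic ring of carbon only) in place of a group of 11 heavy atoms (8 carbon, 2 oxygen, 1 chlorine; one six-membered aromatic ring of carbon only), on an oxygen next to a carbonyl group. The measured steps from compound 1 are all small, and the change of chlorine for bromine is smaller still, so no step beyond the scatter is expected in this assay, and a second limit is as likely as a number. The estimate is an at least 1.0-fold lower number from compound 1 to compound 4 (0.03 log units; that floor lies within the scatter), giving compound 4 an expected 400000 nM with a range from 200000 nM to 800000 nM.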

Compound 4, half-maximal cytotoxic concentration: 326000 nM
For compound 4 the middle estimate is 1.2-fold (0.09 log units) above the measured one; the range from low to high includes it.
By their numbers in this assay, from the lowest: compounds 2, 3 and 4 (each within the scatter of the next). At a limit, above all of these: compound 1.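

With bromine on the ester aryl group, this assay returns a number that cannot be told apart from the two earlier numbers, with bromo in place of methyl giving a 1.3-fold higher number from compound 2 to compound 4 (0.12 log units; within the scatter) and the exchange for the hydroxy-bearing group giving a 1.2-fold higher number from compound 3 to compound 4 (0.09 log units; within the scatter). The change from chlorine can be read only as a floor, an at least 1.3-fold lower number from compound 1 to compound 4 (0.12 log units; that floor lies within the scatter). Compound 1 remains a limit of the assay and not a number: the limit of > 436000 nM in this assay, at which 1 of the 4 values shown sits.

Going by these compounds, whether the chloro-bearing group truly differs from the bromo-, methyl- and hydroxy-bearing groups therefore stays open. On these data alone, it also stays open whether an amine or a carboxylic acid on this aryl group, or a longer chain in place of the methyl of the ester, would move the number beyond the scatter.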